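From iodo to methylsulfanyl in a cell toxicity test

The compounds below may be only part of what the source reports. "The series", "measured", "known", "first", "only" and "open" are said of these compounds alone.

Of the compounds shown here, three with a shared core have been tested in an ADME assay on L929 cells (Mus musculus) for cytotoxicity, read by resazurin assay, with a stated time of 72 h (on this read-out lower numbers stand for stronger inhibition and higher numbers for weaker inhibition), so far. Compound 1 `O=C(/C=C/c1ccc2c(c1)B(O)OC2)c1ccc(OCc2ccccc2)cc1` gives > 10 ug/mL as a limit of the assay, not a number. Compound 2 `O=C(/C=C/c1ccc2c(c1)B(O)OC2)c1ccco1` gives > 10 ug/mL as a limit too. Compound 3 `O=C(/C=C/c1ccc2c(c1)B(O)OC2)c1ccc(I)cc1` also gives only a limit, > 10 ug/mL in this case. Compound 3 therefore has no exact value, and the same is true of the other two.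

The unmeasured compound 4 `CSc1ccc(C(=O)/C=C/c2ccc3c(c2)B(O)OC3)cc1` differs from compound 3 by one change: methylsulfanyl in place of iodo on an aromatic carbon at that single place. Two measured steps reach compound 3, namely a step that the two limits leave unreadable from compound 1 to compound 3 and a step that the two limits leave unreadable from compound 2 to compound 3 and so neither offers a size to carry over.

Because the limit of > 10 ug/mL in this assay, at which 3 of the 3 values shown sit, holds across the series, no step beyond the scatter is expected in this assay and compound 4 will probably report a limit as well. The expected change is a step that the limit leaves unreadable from compound 3 to compound 4 as an estimate only. The estimate for compound 4 is 15 ug/mL with an expected range from 8 ug/mL to 40 ug/mL if a number is obtained at all.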

Compound 4, half-maximal inhibitory concentration: > 10 ug/mL
Compound 4 ended at the assay's limit; the forecaster's own chance of this, stated with the estimate: 85%; the middle value does not contradict the limit.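

The steps to compound 4 from compound 3 and from compound 1 cannot be read, since each compound gives only a limit of the assay, not a number: the limit of > 10 ug/mL in this assay, at which 4 of the 4 values shown sit.

Left open is what exact value any of these compounds would give in this assay, and so whether swapping iodo for methylsulfanyl changes anything there.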